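A few compounds are considered here, and "the series" means these few. Any claim that something is new, unique, unknown or untested is made for them only; others in the source may bear on it.

Of the compounds shown here, three built on one shared core have been measured so far. Compound 1 `CC1=C(N2CC2)C(=O)C(N2CC2)=C(N2CC2)C1=O` gives 6.77 in a functional assay on L1210 cells (Mus musculus), with a stated time of 12 days; a higher number here means a more potent compound, by a factor of ten per unit of this negative logarithm, a lower number a less potent compound. Compound 2 `CCC1=C(N2CC2)C(=O)C(CC)=C(N2CC2)C1=O` gives 5.46 in this assay, and compound 3 `CC1=C(N2CC2)C(=O)C(C(C)C)=C(N2CC2)C1=O` gives 5.6 in this assay. Compound 2 stands lowest of the three numbers: compound 3 lies nearest to it, within the scatter, while compound 1 lies furthest, higher and beyond the scatter. For the measured compounds named here, the only step between measured compounds that differ in a single place is a number 1.17 log units lower from compound 1 to compound 3 (beyond the scatter), a large loss.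

Compound 4 `CCC1=C(N2CC2)C(=O)C(C(COC(N)=O)OC)=C(N2CC2)C1=O` has not yet been measured in this assay. It differs from compound 2 as follows: a group of 8 heavy atoms (4 carbon, 1 nitrogen, 3 oxygen; no ring) in place of a group of 2 heavy atoms (2 carbon; no ring), on a double-bonded ring carbon. Going by the values given here, no measured step concerns such a change; the step from compound 1 to compound 3 concerns isopropyl in place of aziridin-1-yl and so gives no direct guide, and compounds 2 and 3, which differ in more than one place, show values within the scatter of each other. The data therefore leave the direction open. Compound 4 is expected to give about 5.9 in this assay, within a range from 5.2 to 6.6. The expected step is a number 0.44 log units higher from compound 2 to compound 4 (beyond the scatter), which may well fall within the scatter.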

Compound 4, logarithm of the reciprocal of the active concentration, log(1/C): 6.16
For compound 4 the middle estimate is 0.26 log units below the measured one, and the stated range covers the measured number.
By their numbers in this assay, from the lowest: compounds 2 and 3 (each within the scatter of the next); then compound 4; then compound 1.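

For the compounds shown here, the step of a number 0.70 log units higher from compound 2 to compound 4 (beyond the scatter) in this assay is the first measured change in which the ethyl group on this double-bonded ring carbon is replaced, and it shows that this place tolerates a far larger open-chain group without loss. Going by these compounds alone, the only earlier single-place step, a number 1.17 log units lower from compound 1 to compound 3 (beyond the scatter) in this assay, went the other way, so a new group on a double-bonded ring carbon is no longer seen only as a loss, although that step replaces aziridin-1-yl rather than ethyl and cannot be set directly against this one. No measurement shown here speaks to what lies behind the gain.

The compounds shown leave open whether the gain goes with the sheer length of the entering group or with its oxygen and nitrogen atoms, a question that a plain butyl chain or a hydroxyethyl chain at this place would bear on. They also leave open whether the same group would give a similar step with a methyl group in place of the remaining ethyl group.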